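Swapping Fluoro for Bromo at an Assay Limit

The source may report more compounds than this note shows. Statements on the series, on what has been measured and on what is new or still open speak of the compounds shown alone.

Values in a functional assay on U-251 cells (Homo sapiens) for antiproliferative activity, read by MTT assay, with a stated time of 48 h; on this read-out lower numbers stand for stronger inhibition and higher numbers for weaker inhibition:
- compound 1 `COc1cc(-c2cccc3nc(-c4ccccc4)oc23)cc(OC)c1OC`: 3500 nM
- compound 2 `COc1ccc(-c2nc3cccc(-c4cc(OC)c(OC)c(OC)c4)c3o2)cc1OC`: 1300 nM
- compound 3 `COc1cc(-c2cccc3nc(-c4ccc(F)cc4)oc23)cc(OC)c1OC`: > 25000 nM (a limit)

Compound 3 stands at the limit of > 25000 nM in this assay, at which 1 of the 3 values shown sits, so its reading is a limit and not a number. Compound 4 `COc1cc(-c2cccc3nc(-c4ccc(Br)cc4)oc23)cc(OC)c1OC` has not yet been measured. It differs from compound 3 at one place: bromo in place of fluoro on an aromatic carbon. This is bromo in place of fluoro on an aromatic carbon, para to a large group.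

Within the data shown here, no measured compound carries bromo, so only indirect evidence bears on this change. The closest guide is an at least 7.1-fold higher number from compound 1 to compound 3 (0.85 log units; beyond the scatter), seen with fluoro in place of hydrogen. The larger at least 19-fold higher number from compound 2 to compound 3 (1.28 log units; beyond the scatter) involves 4-fluorophenyl in place of 3,4-dimethoxyphenyl. The smaller 2.7-fold lower number from compound 1 to compound 2 (0.43 log units; beyond the scatter) shows that this group can also shift the number downward. A modest move toward stronger inhibition therefore seems likely, although another limit reading remains possible. The expected step is an at least 2.7-fold lower number from compound 3 to compound 4 (0.44 log units; beyond the scatter). The estimate for compound 4 is 9000 nM, with an expected range of 2500 nM to 25000 nM.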

Compound 4, half-maximal inhibitory concentration: > 25000 nM
Compound 4 was reported as a limit; the forecaster's own chance of this, stated with the estimate: 35%; middle value at least 2.7-fold (0.44 log units) away from the limit.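

In this assay compound 4 gives > 25000 nM, which is a limit and not a number. The weakening seen with fluoro therefore returns with bromo, which gives an at least 7.1-fold higher number from compound 1 to compound 4 (0.85 log units; beyond the scatter) with bromo in place of hydrogen, and an at least 19-fold higher number from compound 2 to compound 4 (1.28 log units; beyond the scatter) with 4-bromophenyl in place of 3,4-dimethoxyphenyl. Compound 3 and compound 4 both sit at the limit, so the steps between them cannot be read and the assay gives no ranking of fluoro against bromo: the limit of > 25000 nM in this assay, at which 2 of the 4 values shown sit.

The compounds shown leave open whether a different group on this aromatic carbon, such as an amine or a carboxylic acid, would bring the reading back to a measurable number. They also leave open whether such a group could match or improve on the hydrogen of compound 1.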